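The source may report more compounds than this note shows. Statements on the series, on what has been measured and on what is new or still open speak of the compounds shown alone.

Values so far in a functional assay on CCRF-CEM cells (Homo sapiens) for antiproliferative activity, with a stated time of 72 h (on this read-out higher numbers stand for weaker inhibition and lower numbers for stronger inhibition), for the measured compounds
- compound 1 `Cc1ccc(CNc2ncnc3c2ncn3[C@@H]2O[C@H](CO)[C@@H](O)[C@H]2O)cc1` gives > 166000 nM as a limit of the assay, not a number
- compound 2 `OC[C@H]1O[C@@H](n2cnc3c(NCc4ccc(Cl)c(Cl)c4)ncnc32)[C@H](O)[C@@H]1O` gives 3800 nM as a number

Among the compounds with values here, compound 2 carries the only number so far in this assay and so has no measured neighbour to rank against. Within the data shown here, compound 3 `COc1ccc(CNc2ncnc3c2ncn3[C@@H]2O[C@H](CO)[C@@H](O)[C@H]2O)c(OC)c1` has 2,4-dimethoxyphenyl in place of 3,4-dichlorophenyl on a saturated chain carbon bound to a nitrogen on an aromatic ring as its one change. Among the measured compounds shown here, the only measured step at this place is an at least 43-fold lower number from compound 1 to compound 2 (1.64 log units; beyond the scatter) and it was large. A large move to a higher number, meaning weaker inhibition, is therefore expected in this assay once 3,4-dichlorophenyl leaves. The expected step is an 11-fold higher number from compound 2 to compound 3 (1.02 log units; beyond the scatter) in this estimate. Compound 3 is estimated at 40000 nM with an expected range from 6000 nM to 166000 nM overall.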

Compound 3, half-maximal inhibitory concentration: > 166000 nM
Compound 3 was reported as a limit (the forecaster's own chance of this, stated with the estimate: 45%); middle value at least 4.1-fold (0.61 log units) away from the limit.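

In this assay, a second group in place of 3,4-dichlorophenyl, on a saturated chain carbon bound to a nitrogen on an aromatic ring, gives an at least 43-fold higher number from compound 2 to compound 3 (1.64 log units; beyond the scatter). The number at compound 2 therefore now stands against two different replacements, one of them carrying methoxy groups rather than methyl. Compound 1 and compound 3 cannot be ordered, since both are limits and the step between them cannot be read; only compound 2 lies clear of the shared limit: the limit of > 166000 nM in this assay, at which 2 of the 3 values shown sit.

As far as these compounds go, whether 4-chlorophenyl or 3-chlorophenyl alone would give a number stays open. So does the effect of an amine on the phenyl ring or a longer chain to the nitrogen.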